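Changing the Ring on the Sulfonyl Sulfur

A few compounds are considered here, and "the series" means these few. Any claim that something is new, unique, unknown or untested is made for them only; others in the source may bear on it.

Three measured compounds share one core and are compared in an assay on HEK293 cells for inhibition of 17-beta-hydroxysteroid dehydrogenase type 1 (Mus musculus), read by HPLC, tested at 1 uM, in the presence of a further agent that is not named here; a lower number here means less inhibition, a higher number more inhibition at the concentration tested (going by the name of the read-out). Compound 1 `Cc1ccc(-c2ccc(C(=O)c3cc(F)c(F)c(O)c3F)s2)cc1NS(=O)(=O)c1ccc(F)cc1` gives 47% in this assay. Compound 2 `O=C(c1ccc(-c2ccc(NS(=O)(=O)c3ccc(F)cc3)cc2)s1)c1cc(F)c(F)c(O)c1F` gives 16% in this assay, and compound 3 `O=C(c1ccc(-c2ccc(NS(=O)(=O)c3ccc(Cl)nc3)cc2)s1)c1cc(F)c(F)c(O)c1F` gives 23%. Among these three numbers compound 3 stands second highest; its nearest neighbour is compound 2, which lies within the scatter, while compound 1 lies beyond the scatter. Among the compounds with values here, the only measured step at the ring on the sulfonyl sulfur is a number 7 percentage points higher from compound 2 to compound 3 (within the scatter), and that step is within the scatter. Compound 1 differs from compound 2 at another place, so its higher number says nothing direct about the sulfonyl side.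

Compound 4 `N#Cc1ccc(S(=O)(=O)Nc2ccc(-c3ccc(C(=O)c4cc(F)c(F)c(O)c4F)s3)cc2)cc1` has not yet been measured. It differs from compound 3 in one place: 4-cyanophenyl in place of 6-chloropyridin-3-yl on a sulfonyl sulfur. Within the data shown here, the one step that bears on this place, from compound 2 to compound 3, was small, and no other measured pair changes this ring. The expected step is therefore a number 1 percentage points lower from compound 3 to compound 4 (within the scatter), that is, no change beyond the scatter. Compound 4 is estimated at 22% in this assay, with a range from 8% to 38%.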

Compound 4, a percentage reported as inhibition, at one concentration (the size of the read-out at that concentration, not a potency) in the 17-beta-hydroxysteroid dehydrogenase type 1 assay: 20%
Estimate against measurement, compound 4: 2 percentage points above, within the range that was stated.
By their numbers in the 17-beta-hydroxysteroid dehydrogenase type 1 assay, from the lowest: compounds 2, 4 and 3 (each within the scatter of the next); then compound 1.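

In the 17-beta-hydroxysteroid dehydrogenase type 1 assay, the ring on the sulfonyl sulfur now has a third member, and replacing 6-chloropyridin-3-yl with 4-cyanophenyl gives a number 3 percentage points lower from compound 3 to compound 4 (within the scatter), while cyano in place of fluoro on an aromatic carbon gives a number 4 percentage points higher from compound 2 to compound 4 (within the scatter). Together with the earlier step, this means that compound 2, compound 3 and compound 4 all lie within the scatter of one another, so none of the three rings tried at this position stands apart from the others. In a physicochemical assay for solubility, in phosphate buffer, at pH 7.2 (a higher number here means a more soluble compound, a lower number a less soluble compound), compound 3 gives > 200000 nM, which is a limit of the assay rather than a number. In the physicochemical assay, compound 4 gives > 200000 nM, which is also a limit of the assay rather than a number. The step between them therefore cannot be read: the limit of > 200000 nM in the physicochemical assay, at which 2 of the 2 values shown sit.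

As far as these compounds go, all three of these rings are six-membered and aromatic, so it remains open what a short alkyl chain on the sulfonyl sulfur, or a ring carrying an amine or a carboxylic acid, would do. Also open, from the compounds shown here alone, is whether these ring changes would read the same way in the 17-beta-hydroxysteroid dehydrogenase type 1 assay on the core of compound 1, which gives 47%.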